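Swapping a Six-Membered Arm for a Five-Membered One

The source may report more compounds than this note shows. Statements on the series, on what has been measured and on what is new or still open speak of the compounds shown alone.

Within the data shown here, compound 1 `COCc1ccc(CN(Cc2nc3ccccc3[nH]2)C2CCCc3cccnc32)c(CN)c1` is one of two compounds measured in a functional assay on CEM-CCRF cells for antagonist activity at C-X-C chemokine receptor type 4 (Homo sapiens), read by calcium flux (on this read-out higher numbers stand for weaker inhibition and lower numbers for stronger inhibition), and compound 1 gives 21 nM, the higher of the two numbers. Among the measured compounds shown here, compound 2 `CO/N=C/c1ccc(CN(Cc2nc3ccccc3[nH]2)C2CCCc3cccnc32)c(CN)c1` gives 5 nM; the only measured step is a 4.2-fold lower number from compound 1 to compound 2 (0.62 log units; beyond the scatter), and it alters a substituent on the aromatic ring while keeping that ring in place. Compound 3 `NCc1occc1CN(Cc1nc2ccccc2[nH]1)C1CCCc2cccnc21` has not been measured. It differs from compound 1 by a group of 7 heavy atoms (5 carbon, 1 nitrogen, 1 oxygen; one five-membered aromatic ring with 1 hetero atom) in place of a group of 11 heavy atoms (9 carbon, 1 nitrogen, 1 oxygen; one six-membered aromatic ring of carbon only), on a saturated chain carbon bound to an amine nitrogen, so the very ring whose substituent was varied between compound 1 and compound 2 is itself exchanged. For the measured compounds named here, the step from compound 1 to compound 2 therefore bears only indirectly on this change: it shows that this region responds to alteration, but no measured step describes a ring exchange. For compound 3 a modest rise in the number is expected, a step of a 2.1-fold higher number from compound 1 to compound 3 (0.33 log units; beyond the scatter). Compound 3 is estimated at 45 nM, with a range from 10 nM to 200 nM.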

Compound 3, half-maximal inhibitory concentration: 21 nM
The estimate for compound 3 lay 2.1-fold (0.33 log units) above the measured number, within the range that was stated.
By their numbers in this assay, from the lowest: compound 2; then compounds 1 and 3 (each within the scatter of the next).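

In this assay, the step from the six-membered group to the five-membered one gives no change at the digits printed from compound 1 to compound 3 (within the scatter). Compounds 1 and 2 had shown only that changing a substituent on the six-membered aromatic ring of carbon only can alter the number, whereas compound 3 shows that the entire ring can be exchanged at this saturated chain carbon bound to an amine nitrogen without a change beyond the scatter, even though a group of 7 heavy atoms replaces a group of 11 heavy atoms. No measurement offered here explains this outcome.

Going by these compounds, it remains open whether a thiophene ring, or a longer chain carrying the amine, would hold the number in the same way. On these data alone, it is also open whether the substituent of compound 2, placed on the five-membered ring, would give a lower number.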